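The source may hold more compounds than are shown below. What is called first, only, known or untested is meant among the compounds shown, and "the series" means these compounds.

Measured compounds:
compound 1 `NC1CCN(C(=O)c2ccc(-c3ccc4ncc(-c5ccc6cnccc6c5)n4c3)cc2)CC1`: 2060 nM
compound 2 `NC1CCN(C(=O)c2ccc(-c3ccc4ncc(-c5ccc6cnccc6c5)n4n3)cc2)CC1`: 2090 nM

In a functional assay on TMD8 cells (Homo sapiens) for antiproliferative activity, read by MTT assay, with a stated time of 72 h (a lower number here means a stronger inhibitor, a higher number a weaker inhibitor), compound 1 gives 2060 nM, the lower of the two numbers recorded so far, while compound 2 gives 2090 nM. The gap between them lies within the scatter, so the two cannot be told apart on these data, and the change of the shared core between them makes no visible difference here.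

Compound 3 `N[C@@H]1CCCN(C(=O)c2ccc(-c3ccc4ncc(-c5ccc6cnccc6c5)n4c3)cc2)C1` has not yet been measured in this assay. Relative to compound 1 the change is 3-aminopiperidin-1-yl in place of 4-aminopiperidin-1-yl on a carbonyl carbon. The two compounds keep the same atoms, joined differently, and compound 3 carries one defined stereocentre.

Going by the values given here, no measured pair shows this change, so there is nothing to fix its size or direction. Among the compounds with values here, both measured compounds sit close together, and with no comparable step on record the expectation is that the step of a 1.0-fold higher number from compound 1 to compound 3 (0.01 log units; within the scatter) stays within the scatter, with no direction favoured. On that basis compound 3 is estimated at 2100 nM in this assay, with a range from 600 nM to 7000 nM that allows for the unknown effect of the change.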

Compound 3, half-maximal inhibitory concentration: 2300 nM
Compound 3: the middle estimate sits 1.1-fold (0.04 log units) below what was measured; low and high end bracket the measured number.
By their numbers in this assay, from the lowest: compounds 1, 2 and 3 (each within the scatter of the next).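

In this assay the swap of 3-aminopiperidin-1-yl for 4-aminopiperidin-1-yl on a carbonyl carbon gives a 1.1-fold higher number from compound 1 to compound 3 (0.05 log units; within the scatter) and so leaves the number where it was. Going by these compounds alone, the earlier pair differed only in the shared core, so this is the first reading at the group on the carbonyl, and on this one step the assay does not separate the two aminopiperidine arrangements, even with the defined stereocentre that compound 3 carries. No supporting data bear on this result, so the flat step stands as an observation only.

Open is whether this position responds at all to a larger change, such as a piperazin-1-yl group, a hydroxyl in place of the amine, or a dimethylamino group on the same ring, since both aminopiperidines shown keep the same atoms. Also open, going by these compounds, is what the opposite stereocentre at the 3-amino carbon would read, and whether a flat step at this position would hold on the other core, that of compound 2.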